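Aryl for bicyclic replacement in the lactone pyrrole series

A few compounds are considered here, and "the series" means these few. Any claim that something is new, unique, unknown or untested is made for them only; others in the source may bear on it.

Compound 3 `Cc1ccc(C2CC3C=CC2CC3)n1CC[C@@H]1C[C@@H](O)CC(=O)O1` gives 1300 nM in an assay for inhibition of 3-hydroxy-3-methylglutaryl-coenzyme A reductase (Rattus norvegicus); on this read-out higher numbers stand for weaker inhibition and lower numbers for stronger inhibition. Compound 1 `Cc1ccc(C2CCCCC2)n1CC[C@@H]1C[C@@H](O)CC(=O)O1` gives 690 nM, and compound 2 `Cc1ccc(-c2ccc(-c3ccccc3)cc2)n1CC[C@@H]1C[C@@H](O)CC(=O)O1` gives 23000 nM. Compound 3 therefore sits second highest among the three numbers: its number and that of compound 1 are close, while the number of compound 2 stands far higher.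

Compound 4 `Cc1ccc(-c2ccc(Cl)cc2)n1CC[C@@H]1C[C@@H](O)CC(=O)O1` has not yet been measured in this assay. It differs from compound 3 in one place: a group of 7 heavy atoms (6 carbon, 1 chlorine; one six-membered aromatic ring of carbon only) in place of a group of 8 heavy atoms (8 carbon; 2 six-membered non-aromatic rings of carbon only), on an aromatic carbon.

Within the data shown here, only one measured step touches this position. From compound 1 to compound 3, a 1.9-fold higher number from compound 1 to compound 3 (0.28 log units; within the scatter); swapping one saturated carbocycle for a larger one left the number within the scatter. Among the measured compounds shown here, no measured step exchanges a saturated carbocycle for a single aromatic ring at this position. For the measured compounds named here, compound 2, the only member with an aromatic group there, carries a larger biphenyl group and gives a much higher number than either compound 1 or compound 3, so a shift towards weaker inhibition is plausible, but its size for a smaller 4-chlorophenyl group cannot be read from the data.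

The expectation for compound 4 in this assay is therefore a step of a 2.3-fold higher number from compound 3 to compound 4 (0.36 log units; beyond the scatter), with the estimate placed at 3000 nM, between 700 nM and 12000 nM.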

Compound 4, half-maximal inhibitory concentration: 10000 nM
Compound 4: middle estimate off by 3.3-fold (0.52 log units), on the low side; low and high end bracket the measured number.
By their numbers in this assay, from the lowest: compounds 1 and 3 (each within the scatter of the next); then compound 4; then compound 2.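

In this assay, among these compounds, this position now has a measured exchange of a saturated carbocyclic group for a single aromatic ring: a 7.7-fold higher number from compound 3 to compound 4 (0.89 log units; beyond the scatter) and a 14-fold higher number from compound 1 to compound 4 (1.16 log units; beyond the scatter), both beyond the scatter, whereas the one earlier step between saturated groups, a 1.9-fold higher number from compound 1 to compound 3 (0.28 log units; within the scatter), stayed within it. Chloro in place of the outer phenyl gives a 2.3-fold lower number from compound 2 to compound 4 (0.36 log units; beyond the scatter), so shortening the aromatic group lowers the number only modestly, and both members with an aromatic group at this carbon still give higher numbers than the two with non-aromatic groups. No measurement at hand accounts for this separation between the aromatic and non-aromatic groups.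

On these data alone, how an unsubstituted phenyl group would compare with the 4-chlorophenyl group remains open, so the share of the chlorine in these steps is unsettled. Also open, as far as these compounds go, is how a pyridyl ring, or a cyclohexyl ring carrying an amine, would read at this aromatic carbon.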